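Aryl swap on the shared core

The compounds below may be only part of what the source reports. "The series", "measured", "known", "first", "only" and "open" are said of these compounds alone.

In a functional assay on NCI-H226 cells (Homo sapiens) for inhibition, read by MTT assay, with a stated time of 48 h, tested at 10 uM (on this read-out lower numbers stand for less inhibition and higher numbers for more inhibition at the one concentration tested (going by the name of the read-out)), compound 1 `Cc1cc(F)cc(Nc2cc(NC(=O)Nc3c(Cl)cccc3Cl)ncn2)c1` gives 78.1%, the higher of the two numbers in hand. Going by the values given here, compound 2 `CC(C)(C)c1ccc(Nc2cc(NC(=O)Nc3c(Cl)cccc3Cl)ncn2)cc1` gives 40% in this assay, a number far below that of compound 1 and beyond the usual scatter; no single-point step is recorded between these two, so only the two values themselves are read. Compound 3 `O=C(Nc1cc(Nc2ccc(F)c(Cl)c2)ncn1)Nc1c(Cl)cccc1Cl` has not yet been measured. It differs from compound 1 in one place: 3-chloro-4-fluorophenyl in place of 3-fluoro-5-methylphenyl on a nitrogen on an aromatic ring. Among the compounds with values here, no measured pair shows this change, so the expectation rests on the two known values alone. Compound 1, with a 3-fluoro-5-methylphenyl on that nitrogen, stands highest; compound 2, with a tert-butylphenyl there, stands far lower. Compound 3 keeps a phenyl carrying a fluorine and exchanges the methyl for a chlorine. For compound 3 a modest downward step a number 12.1 percentage points lower from compound 1 to compound 3 (beyond the scatter) from compound 1 is expected in this assay, short of the fall seen for compound 2. Compound 3 is estimated at 66%, with a range from 42% to 86%.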

Compound 3, a percentage reported as inhibition, at one concentration (the size of the read-out at that concentration, not a potency): 47.3%
The estimate for compound 3 lay 18.7 percentage points above the measured number; the range from low to high includes it.
By their numbers in this assay, from the lowest: compounds 2 and 3 (each within the scatter of the next); then compound 1.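

In this assay, going by these compounds alone, 3-chloro-4-fluorophenyl in place of 3-fluoro-5-methylphenyl on the nitrogen gives a number 30.8 percentage points lower from compound 1 to compound 3 (beyond the scatter) and is the first single-change step, showing that this position responds strongly to a change between two groups with the same heavy-atom count. Keeping a fluorine on the phenyl ring is therefore not enough to hold the number of compound 1: compound 3 at 47.3% lies within the scatter of compound 2 at 40% despite the different tert-butylphenyl group on that nitrogen. Nothing at hand accounts for the size of this step.

The compounds shown do not separate the loss of the methyl from the entry of the chlorine or from the different placing of the fluorine, as no phenyl group carrying only one of these changes stands among them. From the compounds shown here alone, it also stays open how this position would respond to a phenyl group carrying a methoxy group or an amine, which would test the series beyond halogen and alkyl groups.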